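A few compounds are considered here, and "the series" means these few. Any claim that something is new, unique, unknown or untested is made for them only; others in the source may bear on it.

Three compounds have been measured in a functional assay on HEK293 cells with D(4) dopamine receptor (Homo sapiens) as the target, read by FLIPR; on this read-out lower numbers stand for smaller maximal responses and higher numbers for larger maximal responses:

Compound 1, `CO/N=C(\CCN1CCN(c2ccccn2)CC1)c1ccc(Cl)cc1`, gives 87%.
Compound 2, `CO/N=C(/c1ccc(Cl)cc1)C(O)CN1CCN(c2ccccn2)CC1`, gives 94%.
Compound 3, `CO/N=C(/c1ccc(Cl)cc1)C(CN1CCN(c2ccccn2)CC1)OC`, gives 83%.

Compound 2 holds the highest of the three numbers, although the step of a number 7 percentage points higher from compound 1 to compound 2 (within the scatter) stays within the scatter, so compound 1 and compound 2 cannot be ranked. The step of a number 11 percentage points lower from compound 2 to compound 3 (beyond the scatter) is the only one that reaches beyond the scatter, and the step of a number 4 percentage points lower from compound 1 to compound 3 (within the scatter) again stays within it.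

Compound 4, `CO/N=C(/c1cccnc1)C(O)CN1CCN(c2ccccn2)CC1`, differs from compound 2 in one place: pyridin-3-yl in place of 4-chlorophenyl on a carbon with a double bond to nitrogen. Going by the values given here, none of the measured steps touches this part of the molecule; all three concern the saturated chain carbon and its hydroxy or methoxy group. Among the compounds with values here, there is therefore no step in the data that bears on the exchange of the aromatic ring, and no step beyond the scatter is expected from it. The expected step is a number 4 percentage points lower from compound 2 to compound 4 (within the scatter). Compound 4 is estimated to give 90% in this assay, with a range from 74% to 102%.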

Compound 4, largest response reached (reported as efficacy), in percent of the reference or control that the assay uses: 80%
Compound 4: the middle estimate sits 10 percentage points above what was measured; the measured number falls inside the stated range.
By their numbers in this assay, from the lowest: compounds 4, 3, 1 and 2 (each within the scatter of the next, the first and the last beyond it).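

At this place, on the carbon with a double bond to nitrogen, the aromatic ring has a measurable effect in this assay: swapping 4-chlorophenyl for pyridin-3-yl moves the number beyond the scatter (a number 14 percentage points lower from compound 2 to compound 4 (beyond the scatter)). Going by these compounds alone, all earlier steps concerned the saturated chain carbon, so this is the first sign that the maximal response also follows a change at the aromatic ring, though the step is only modest. Nothing available explains why the number falls.

The exchange both removes the chlorine and brings a hetero atom into the ring, and the compounds shown cannot separate these two changes; plain phenyl or pyridin-4-yl at this place would help to do so. They also leave open whether pyridin-3-yl acts the same way with a methoxy group or a plain hydrogen on the chain carbon.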